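The source may report more compounds than this note shows. Statements on the series, on what has been measured and on what is new or still open speak of the compounds shown alone.

In an ADME assay on microsomes from liver (Canis lupus familiaris) for metabolic stability, with a stated time of 10 min (on this read-out lower numbers stand for a less stable compound and higher numbers for a more stable compound), compound 1 `FC(F)(F)c1ccccc1-c1ccc2[nH]c(C3=NOC4(CCCCC4)C3)nc2c1` gives 71% and compound 2 `FC(F)Oc1ccccc1-c1ccc2[nH]c(C3=NOC4(CCCCC4)C3)nc2c1` gives 81% so the two stand within the scatter of each other. Compound 3 `FC(F)(F)c1ccccc1-c1cc(Cl)c2[nH]c(C3=NOC4(CCCCC4)C3)nc2c1` keeps the core of compound 1 and carries one change: chloro in place of hydrogen on an aromatic carbon on an aromatic carbon, ortho to a fused ring and meta to a 2-(trifluoromethyl)phenyl group. Within the data shown here, the only measured step is a number 10 percentage points higher from compound 1 to compound 2 (within the scatter) and it concerns difluoromethoxy in place of trifluoromethyl, a different change. Among the measured compounds shown here, no measured compound carries chloro, so the data give no direct size for this replacement. For the measured compounds named here, with only that step of a number 10 percentage points higher from compound 1 to compound 2 (within the scatter) as a guide, the estimated step of a number 1 percentage points higher from compound 1 to compound 3 (within the scatter) is expected to stay within the scatter, with no direction assigned. For compound 3 the estimate in this assay is 72% with an expected range from 55% to 88% around it.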

Compound 3, percent of the compound remaining: 100%
Compound 3: the middle estimate sits 28 percentage points below what was measured, outside the stated range (above it).
By their numbers in this assay, from the lowest: compounds 1 and 2 (each within the scatter of the next); then compound 3.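

Working notes: in this assay, chloro in place of hydrogen on this aromatic carbon, ortho to a fused ring and meta to a 2-(trifluoromethyl)phenyl group, gives a number 29 percentage points higher from compound 1 to compound 3 (beyond the scatter) and is the first change in the series with a step beyond the scatter. By contrast, difluoromethoxy in place of trifluoromethyl gives a number 10 percentage points higher from compound 1 to compound 2 (within the scatter) on the other aryl ring, so this position on the shared core responds to the addition of a single chlorine in a way the earlier pair did not reveal. No available measurement explains the step.
Open, from the compounds shown here alone, is whether a methyl, methoxy, fluoro or amine group at the same aromatic carbon would give a similar step. Also open, going by these compounds, is whether chloro gives the same step when difluoromethoxy replaces trifluoromethyl, as in compound 2.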